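Swapping Carbamoyl for a Boron Group on the Aryl Ring

The compounds below may be only part of what the source reports. "The series", "measured", "known", "first", "only" and "open" are said of these compounds alone.

compound 1 `COc1ccc(-c2cncnc2-c2cc(OC)c(OC)c(OC)c2)cc1Cl` at 320 nM as measured
compound 2 `COc1cc(-c2ncncc2-c2ccc(C(N)=O)cc2)cc(OC)c1OC` at > 100000 nM as a limit

Compound 2 stands at the limit of > 100000 nM in this assay, at which 1 of the 2 values shown sits, in a functional assay on HeLa cells (Homo sapiens) for antiproliferative activity, read by CCK-8 assay, with a stated time of 72 h (on this read-out higher numbers stand for weaker inhibition and lower numbers for stronger inhibition), and so has a limit rather than a number. Compound 3 `COc1cc(-c2ncncc2-c2ccc(B(O)O)cc2)cc(OC)c1OC` differs from it in one place (a group of 3 heavy atoms (1 boron, 2 oxygen; no ring) in place of a group of 3 heavy atoms (1 carbon, 1 nitrogen, 1 oxygen; no ring), on an aromatic carbon) where the carbamoyl gives way to a group of boron and oxygen, para to a large group. Among the measured compounds shown here, the only measured step bearing on this is an at least 310-fold higher number from compound 1 to compound 2 (2.49 log units; beyond the scatter) and it was large, so a change at this group can move the number far. A large step towards lower numbers, meaning stronger inhibition, is therefore expected. The expected step is (an at least 33-fold lower number from compound 2 to compound 3 (1.52 log units; beyond the scatter)). The estimate for compound 3 is 3000 nM (range 200 nM to 50000 nM).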

Compound 3, half-maximal inhibitory concentration: 4000 nM
Compound 3: middle estimate off by 1.3-fold (0.12 log units), on the low side, within the range that was stated.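

The earlier pair showed only a collapse at this aryl ring, whereas in this assay the boron and oxygen group in place of carbamoyl, para to a large group, restores a measurable number (an at least 25-fold lower number from compound 2 to compound 3 (1.39 log units; beyond the scatter)). The size of that step rests on a limit, since compound 2 has no exact number: the limit of > 100000 nM in this assay, at which 1 of the 3 values shown sits. Even so, the boron-bearing ring does not match the 3-chloro-4-methoxyphenyl ring (a 13-fold higher number from compound 1 to compound 3 (1.10 log units; beyond the scatter)). Going by these compounds, whether an amine or a carboxylic acid on this same aromatic carbon would give a lower number remains open.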